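A few compounds are considered here, and "the series" means these few. Any claim that something is new, unique, unknown or untested is made for them only; others in the source may bear on it.

Compounds measured: compound 1 `Cc1cccc(Oc2ccc(CC3SC(=O)NC3=O)cc2)n1` gives 2620 nM in a functional assay for agonist activity at Free fatty acid receptor 1 (Homo sapiens), read by FLIPR, in the presence of a further agent that is not named here; on this read-out lower numbers stand for an effect already at smaller amounts and higher numbers for an effect only at larger amounts of compound; compound 2 `O=C1NC(=O)C(Cc2ccc(Sc3ccccc3)cc2)S1` gives 5060 nM.

Compound 1 has the lower of these two numbers, but its distance to compound 2 lies within the scatter, so the two stand at much the same level. Compound 3 `Cc1ccccc1Oc1ccc(CC2SC(=O)NC2=O)cc1` has not yet been measured; it differs from compound 1 by 2-methylphenyl in place of 6-methylpyridin-2-yl on an oxygen on an aromatic ring. For the measured compounds named here, no measured pair shows this change, so the step is expected to be small, if any, with a slight lean towards lower numbers in this assay. The step is estimated at a 1.3-fold lower number from compound 1 to compound 3 (0.12 log units; within the scatter). For compound 3 a value of 2000 nM is expected, within 700 nM to 6000 nM.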

Compound 3, half-maximal effective concentration: 124 nM
The estimate for compound 3 lay 16-fold (1.21 log units) above the measured number; the whole stated range lies above it.
By their numbers in this assay, from the lowest: compound 3; then compounds 1 and 2 (each within the scatter of the next).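

In this assay the group on an oxygen on an aromatic ring turns out to matter greatly: 2-methylphenyl in place of 6-methylpyridin-2-yl gives a 21-fold lower number from compound 1 to compound 3 (1.32 log units; beyond the scatter), a large step beyond the scatter. The two groups have the same heavy-atom count, and the entering group has carbon in place of the ring nitrogen and lacks the hydrogen-bond acceptor. Nothing at hand accounts for the size of this step. Going by these compounds, whether the methyl group itself contributes remains open, as does what a chlorine or a methoxy group in its place would give.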